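A few compounds are considered here, and "the series" means these few. Any claim that something is new, unique, unknown or untested is made for them only; others in the source may bear on it.

Measured so far:

Compound 1, `COc1nn(-c2ccccn2)c2cc(-c3ccc(CCC(=O)O)cc3)ccc12`, with 2600 nM
Compound 2, `Cc1cc(-c2ccc(CCC(=O)O)cc2)cc2c1cnn2-c1ccccn1`, with 2600 nM

Both compounds were tested in a functional assay on cells for agonist activity at Free fatty acid receptor 1 (Mus musculus), read by FLIPR and calcium flux, with a stated time of 5 min; on this read-out lower numbers stand for an effect already at smaller amounts and higher numbers for an effect only at larger amounts of compound. Compound 1 gives 2600 nM. Compound 2 gives 2600 nM, which is level with compound 1 at the digits printed; the two values lie within the usual scatter of each other, so no difference between them can be claimed. The two compounds share the same core and the same propanoic acid side chain and differ only in the small group attached to the core, so the numbers show that swapping one such group for another has left the read-out unchanged here.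

Compound 3, `N#Cc1cc(-c2ccc(CCC(=O)O)cc2)cc2c1cnn2-c1ccccn1`, has not yet been measured. It differs from compound 2 by cyano in place of methyl on an aromatic carbon. Within the data shown here, no pair of measured compounds shows what this particular swap does, so the expectation rests only on the fact that the one small-group swap seen so far left the read-out unchanged. Compound 3 is therefore expected to come out close to compound 2, with a step of a 1.2-fold lower number from compound 2 to compound 3 (0.07 log units; within the scatter) that is not expected to go beyond the scatter in either direction. The estimate for compound 3 in this assay is 2200 nM, with a range from 700 nM to 7000 nM.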

Compound 3, half-maximal effective concentration in the Free fatty acid receptor 1 assay: 19000 nM
For compound 3 the middle estimate is 8.6-fold (0.94 log units) below the measured one; the measured number lies above the stated range.
By their numbers in the Free fatty acid receptor 1 assay, from the lowest: compounds 1 and 2 (each within the scatter of the next); then compound 3.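

The carbon that carries the methyl in compound 2 is sensitive to what sits on it: in the Free fatty acid receptor 1 assay, cyano in place of methyl on an aromatic carbon gives a 7.3-fold higher number from compound 2 to compound 3 (0.86 log units; beyond the scatter), so a larger amount of compound is needed for the same effect. Among these compounds, the level values of the earlier compounds gave no sign of this, and it shows that a small group here cannot be exchanged freely. In a physicochemical assay for lipophilicity, using the shake flask method, measured as octanol-water partition, with a stated time of 30 min, at pH 7.4 (on this read-out lower numbers stand for lower lipophilicity and higher numbers for higher lipophilicity), compound 2 gives 2.6 and compound 3 gives 2.2 as measured. The change may be partly due to lower lipophilicity, since cyano brings one hydrogen-bond acceptor that methyl lacks and the swap also moves the read-out in the physicochemical assay: the measured distribution coefficient of compound 2, 2.6, and of compound 3, 2.2, a number 0.40 log units lower (beyond the scatter)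

With a single pair, the effect of lipophilicity cannot be separated from that of the acceptor or of the added heavy atom, so the cause remains a suggestion. As far as these compounds go, it also remains open whether a group such as an ethyl, a chlorine atom or an amine on this same carbon would keep the number of compound 2 or raise it as cyano does, which would show whether methyl is a special case.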